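This account rests on a few compounds, and the source may have more. Where it says the series, first, only, none or still open, it means among the compounds named here.

Compound 1 `CCn1c(=O)/c(=C2\Sc3ccccc3N2C)s/c1=C\c1ccncc1Nc1ccccc1C` carries the shared core, and in a functional assay on PC-3 cells (Homo sapiens) for inhibition (on this read-out lower numbers stand for stronger inhibition and higher numbers for weaker inhibition), compound 1 gives 1200 nM. Compound 2 `CCn1c(=O)/c(=C2\Sc3ccccc3N2C)s/c1=C\c1ccncc1Nc1ccccc1Cl` differs from compound 1 by chloro in place of methyl on an aromatic carbon, and this change gave a 1.5-fold lower number from compound 1 to compound 2 (0.19 log units; within the scatter). Compound 3 `CCn1c(=O)/c(=C2\Sc3cc(F)ccc3N2C)s/c1=C\c1ccncc1Nc1ccccc1C` differs from compound 1 by fluoro in place of hydrogen on an aromatic carbon, the one counted difference between the two cores, and in this assay compound 3 gives 2300 nM, a step of a 1.9-fold higher number from compound 1 to compound 3 (0.28 log units; within the scatter). Compound 2 gives 780 nM in this assay, and compound 3 stands at the highest number of the three measured, with compound 2 beyond the scatter from it.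

Compound 4 `CCn1c(=O)/c(=C2\Sc3cc(F)ccc3N2C)s/c1=C\c1ccncc1Nc1ccccc1Cl` has not yet been measured. It differs from compound 3 by chloro in place of methyl on an aromatic carbon, the same change as from compound 1 to compound 2, appearing here for the second time, at a place described in the same words. Within the data shown here, because a 1.5-fold lower number from compound 1 to compound 2 (0.19 log units; within the scatter) stayed within the scatter, a step of similar size is expected from compound 3 to compound 4, namely a 1.5-fold lower number from compound 3 to compound 4 (0.19 log units; within the scatter), with no measured pair here suggesting anything larger. Compound 4 is therefore estimated to give 1500 nM in this assay, between 700 nM and 3500 nM.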

Compound 4, half-maximal inhibitory concentration: 1200 nM
Compound 4: middle estimate off by 1.3-fold (0.10 log units), on the high side, and the stated range covers the measured number.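

In this assay, chloro in place of methyl carried from one core to the other without a detectable change in the size of the step, with a 1.9-fold lower number from compound 3 to compound 4 (0.28 log units; within the scatter) standing beside the earlier step: the same change on two cores in this assay, a 1.5-fold lower number (0.19 log units; within the scatter) from compound 1 to compound 2 and a 1.9-fold lower number (0.28 log units; within the scatter) from compound 3 to compound 4, 1.2-fold (0.10 log units) apart, within the scatter of two such steps. Fluoro in place of hydrogen behaved in the same way, with a 1.5-fold higher number from compound 2 to compound 4 (0.19 log units; within the scatter) standing beside its earlier counterpart: the same change on two cores in this assay, a 1.9-fold higher number (0.28 log units; within the scatter) from compound 1 to compound 3 and a 1.5-fold higher number (0.19 log units; within the scatter) from compound 2 to compound 4, 1.2-fold (0.10 log units) apart, within the scatter of two such steps. All four steps lie within the scatter, which means that the agreement is between small steps; it does not show that either change has a real effect on inhibition, and two cores cannot show that the steps would hold on any other core or in any other assay.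

The compounds shown leave open how a bromo, a methoxy or a nitrile would compare with chloro and methyl at this place on the aromatic ring. They also leave open whether an amine or a carboxylic acid elsewhere on the shared core would give a step beyond the scatter.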